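A few compounds are considered here, and "the series" means these few. Any claim that something is new, unique, unknown or untested is made for them only; others in the source may bear on it.

Measured compounds:
compound 1 `O=C(OCC1CCCCO1)c1ccccc1`, 3000 nM in an assay on cerebellum for inhibition of Monoglyceride lipase (Rattus norvegicus); on this read-out higher numbers stand for weaker inhibition and lower numbers for stronger inhibition
compound 2 `CCCCC/C=C\C/C=C\C/C=C\C/C=C\CCCC(=O)OCC1COC(C)(C)O1`, 45000 nM in this assay

Of these two numbers compound 2 gives the higher one, and compound 1 the lower. Compound 3 `CCCCC/C=C\C/C=C\C/C=C\C/C=C\CCCC(=O)OC[C@H]1COC(C)(C)O1` has not yet been measured. From compound 2 to compound 3 the change is the two compounds have the same atoms and bonds; at least one stereo element is drawn with a configuration in one of them and without one in the other: 1 of 5 stereo elements differ; a stereocentre at a saturated ring carbon is drawn without a configuration in compound 2 and R in compound 3. For the measured compounds named here, no measured pair shows how such a change plays out here; the account therefore expects either no step beyond the scatter or a modest one towards a lower number, should the configuration drawn be the more active of the two. The expected step is a 1.5-fold lower number from compound 2 to compound 3 (0.18 log units; within the scatter). Compound 3 is estimated at 30000 nM, with a range from 10000 nM to 90000 nM.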

Compound 3, half-maximal inhibitory concentration: 60000 nM
For compound 3 the middle estimate is 2.0-fold (0.30 log units) below the measured one; the range from low to high includes it.
By their numbers in this assay, from the lowest: compound 1; then compounds 2 and 3 (each within the scatter of the next).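

In this assay the step of a 1.3-fold higher number from compound 2 to compound 3 (0.12 log units; within the scatter) shows that drawing this saturated ring carbon as R gives no separation from the form without a drawn configuration. The arachidonoyl-type chain and the rest of the core stay the same, so the pair isolates this one point: the fact that one of compounds 2 and 3 is drawn with a defined configuration and the other without, at the place where they differ.

The compounds shown leave open how the S configuration at this ring carbon would read out. They also leave open whether an amide in place of the ester would move the number at all.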